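From Piperidine to Morpholine on the Thiocarbonyl Carbon

The source may report more compounds than this note shows. Statements on the series, on what has been measured and on what is new or still open speak of the compounds shown alone.

Of the compounds shown here, three have so far been tested in a functional assay on MDA-MB-435S cells (Homo sapiens) for antiproliferative activity, read by MTT assay, with a stated time of 72 h; on this read-out higher numbers stand for weaker inhibition and lower numbers for stronger inhibition. Compound 1 `O=c1cc(CSC(=S)N2CCCCC2)oc2cc(Cl)ccc12` gives 3000 nM, the lowest of the two values that are actual numbers. Compound 3 `CCOC(=O)c1cc(=O)c2cc(CSC(=S)N3CCCC3)ccc2o1` gives 3400 nM in this assay, and the gap to compound 1 lies within the usual scatter of repeated measurements, so the two cannot be ranked against each other. Compound 2 `O=c1c(CSC(=S)N2CCN(C(c3ccc(F)cc3)c3ccc(F)cc3)CC2)coc2ccccc12` reaches only a limit of this assay, > 40000 nM, and no number is known for it. The limit is described as the limit of > 40000 nM in this assay, at which 1 of the 3 values shown sits.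

Compound 4 `O=c1cc(CSC(=S)N2CCOCC2)oc2cc(Cl)ccc12` has not been measured. It differs from compound 1 in one place only: morpholin-4-yl in place of piperidin-1-yl on a thiocarbonyl carbon. Among the measured compounds shown here, no measured pair shows this exchange, so its effect is uncertain. Because the step from compound 1 to compound 3 changes much more of the structure yet gives 3400 nM, a small step is expected here, of a 1.3-fold higher number from compound 1 to compound 4 (0.12 log units; within the scatter), probably within the scatter. Compound 4 is therefore expected to give about 4000 nM, with a range from 1500 nM to 12000 nM.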

Compound 4, half-maximal inhibitory concentration: > 25000 nM
Compound 4: a limit, no number; the forecaster's own chance of this, stated with the estimate: 10%; at least 6.2-fold (0.79 log units) between middle value and limit.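

Among the compounds shown here, this exchange shows that the group on the thiocarbonyl carbon matters for activity, which the earlier compounds could not show because none of them formed a pair differing in one place. Both groups are six-membered non-aromatic rings, and morpholin-4-yl differs from piperidin-1-yl by an oxygen in the ring and one hydrogen-bond acceptor, yet this assay records an at least 8.3-fold higher number from compound 1 to compound 4 (0.92 log units; beyond the scatter). The value for compound 4 is a limit and not a number, so the step gives only the smallest possible size: the limit of > 25000 nM in this assay, at which 1 of the 4 values shown sits.

The compounds shown do not tell whether the ring oxygen itself accounts for this loss or how far the loss extends. Thiomorpholin-4-yl, with sulfur in the ring, or an open-chain diethylamino group on the same thiocarbonyl carbon of the core of compound 1 would help to answer that.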